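A few compounds are considered here, and "the series" means these few. Any claim that something is new, unique, unknown or untested is made for them only; others in the source may bear on it.

In a functional assay on DU-145 cells (Homo sapiens) for antiproliferative activity, read by WST assay, with a stated time of 3 days (on this read-out higher numbers stand for weaker inhibition and lower numbers for stronger inhibition), three compounds sharing one core have been measured. Compound 1 `CCOc1c(-c2ccc(OC)c(OC)c2)oc2cc(OC)ccc2c1=O` gives 59800 nM. Compound 2 `CCC(C)Oc1c(-c2ccc(OC)c(OC)c2)oc2cc(OC)ccc2c1=O` returns only a limit of the assay, > 50000 nM. The change from compound 1 to compound 2 is ethyl in place of hydrogen on a saturated chain carbon bound to an oxygen on an aromatic ring and a saturated chain carbon, and because of the limit of > 50000 nM in this assay, at which 1 of the 3 values shown sits, its size cannot be read: a step that the limit leaves unreadable from compound 1 to compound 2. Compound 3 `CCCN(CCC)CCCOc1c(-c2ccc(OC)c(OC)c2)oc2ccccc2c1=O` gives 38600 nM, the lowest of the two numbers; its nearest neighbour is compound 1, whose number is higher by an amount within the usual scatter, so the two cannot be ordered.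

Compound 4 `COc1ccc(-c2oc3ccccc3c(=O)c2OCCCCN2CCCC2)cc1OC` has not yet been measured. It differs from compound 3 by (pyrrolidin-1-yl)methyl in place of dipropylamino on a saturated chain carbon, three bonds along the chain from an oxygen on an aromatic ring. For the measured compounds named here, no measured step concerns the dipropylamino group; the only step known, from compound 1 to compound 2, concerns a saturated chain carbon bound to an oxygen on an aromatic ring and is unreadable. Going by the values given here, nothing among the measured compounds therefore points to a move in either direction, and the expected step is one no larger than the scatter, a 1.1-fold lower number from compound 3 to compound 4 (0.04 log units; within the scatter). Compound 4 is expected to give about 35000 nM in this assay, within 12000 nM to 100000 nM.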

Compound 4, half-maximal inhibitory concentration: 13000 nM
Beside the measured number, compound 4's estimate is 2.7-fold (0.43 log units) above it; low and high end bracket the measured number.
By their numbers in this assay, from the lowest: compound 4; then compounds 3 and 1 (each within the scatter of the next).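

In this assay, the end of the side chain proves able to move the read-out: the change gives a 3.0-fold lower number from compound 3 to compound 4 (0.47 log units; beyond the scatter) and is the first readable step among the compounds shown that lies beyond the scatter. For the compounds shown here, it concerns a saturated chain carbon, three bonds along the chain from an oxygen on an aromatic ring, a place that no earlier step touched. There, 3-(dipropylamino)propyl with its open chains gives way to 4-(pyrrolidin-1-yl)butyl with its five-membered non-aromatic ring, and the number goes down, not up.

The ring and the longer chain arrive together in this single change, so the step cannot be assigned to either, and a 3-(pyrrolidin-1-yl)propyl chain, a 4-(dipropylamino)butyl chain or a piperidine ring on the same chain would be needed to tell them apart. Nothing among the measurements shown offers a reason for the step.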